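Exchanging Thiophen-2-yl for Phenyl on the Shared Core

A few compounds are considered here, and "the series" means these few. Any claim that something is new, unique, unknown or untested is made for them only; others in the source may bear on it.

Of the compounds shown here, three sharing one core have been measured in a functional assay on MDA-MB-231 cells (Homo sapiens) for inhibition, read by MTT assay, with a stated time of 48 h; on this read-out lower numbers stand for stronger inhibition and higher numbers for weaker inhibition. Compound 1 `CS(=O)(=O)c1ccc(-c2nc3ccccn3c2Sc2ccccc2)cc1` gives 72700 nM, compound 2 `c1ccc(Sc2c(-c3cccs3)nc3ccccn23)cc1` gives 69200 nM and compound 3 `Clc1ccc(Sc2c(-c3cccs3)nc3ccccn23)cc1` gives 73100 nM. Compound 3 therefore stands within the scatter of both others, and the three numbers cannot be ranked.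

The next compound, compound 4 `Clc1ccc(Sc2c(-c3ccccc3)nc3ccccn23)cc1`, differs from compound 3 in one place: phenyl in place of thiophen-2-yl on an aromatic carbon. It carries phenyl in place of thiophen-2-yl on an aromatic carbon.

Within the data shown here, no measured pair tests this exchange directly. Among the measured compounds shown here, the one measured step, a 1.1-fold higher number from compound 2 to compound 3 (0.02 log units; within the scatter), puts chloro in place of hydrogen on an aromatic carbon and stays within the scatter. Compound 1, which carries no thiophen-2-yl, gives 72700 nM, against compound 2 at 69200 nM, and these two values also lie within the scatter of each other. On this evidence, no step beyond the scatter is expected in this assay, and no direction can be assigned. The expected step is a 1.1-fold lower number from compound 3 to compound 4 (0.03 log units; within the scatter). Compound 4 is estimated at 68000 nM, with an expected range of 33000 nM to 125000 nM.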

Compound 4, half-maximal inhibitory concentration: 57600 nM
For compound 4 the middle estimate is 1.2-fold (0.07 log units) above the measured one; measured number inside the range.
By their numbers in this assay, from the lowest: compounds 4, 2, 1 and 3 (each within the scatter of the next).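

In this assay, among these compounds, the exchange of thiophen-2-yl for phenyl on this aromatic carbon, next to the ring nitrogen, gives a 1.3-fold lower number from compound 3 to compound 4 (0.10 log units; within the scatter) and so provides the first direct reading of a change at this position. With the chloro group held in place, this read-out does not separate the two aromatic rings, even though the sulfur and the hydrogen-bond acceptor counted on thiophen-2-yl leave with the change and the ring grows from five-membered to six-membered. No evidence is at hand that bears on this result.

All the compounds shown keep an aromatic ring on this carbon, so it remains open whether an amine, a carboxylic acid or a longer alkyl chain there would give a step beyond the scatter. Among the compounds shown here, it also remains open whether chloro in place of hydrogen on the sulfur-linked ring would read the same with phenyl on the core as it does with thiophen-2-yl in a 1.1-fold higher number from compound 2 to compound 3 (0.02 log units; within the scatter), the only such pair available.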